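This account rests on a few compounds, and the source may have more. Where it says the series, first, only, none or still open, it means among the compounds named here.

Measured compounds in an ADME assay on the whole organism (Rattus norvegicus, strain Sprague-Dawley) for pharmacokinetics, using cassette dosing, at a dose of 0.5 mg/kg by the intravenous route; a lower number here means slower removal, a higher number faster removal of the compound:
compound 1, `O=C(Nc1ccc2[nH]c(=O)oc2c1)C(=O)N1CCN(c2ccc(Cl)cc2)CC1`: 7.2 mL/min/kg
compound 2, `C[C@@H]1CN(c2ccc(Cl)cc2)CCN1C(=O)C(=O)Nc1ccc2[nH]c(=O)oc2c1`: 5.4 mL/min/kg
compound 3, `C[C@H]1CN(c2ccc(Cl)cc2)CCN1C(=O)C(=O)Nc1ccc2[nH]c(=O)oc2c1`: "not determined" (no result reported)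

Compound 2 gives the lowest of the two numbers in this assay, and its nearest neighbour is compound 1: a 1.3-fold lower number from compound 1 to compound 2 (0.12 log units; within the scatter). Compound 3 carries no number in this assay; (the fact that compounds 2 and 3 differ only in the configuration as drawn).

Compound 4, `C[C@@H]1CN(c2ccc(Cl)c(F)c2)CCN1C(=O)C(=O)Nc1ccc2[nH]c(=O)oc2c1`, is reached from compound 2 by one change: fluoro in place of hydrogen on an aromatic carbon. Going by the values given here, no measured step touches such a change; the only measured step, a 1.3-fold lower number from compound 1 to compound 2 (0.12 log units; within the scatter), concerns a methyl on a saturated ring carbon and stays within the scatter. For compound 4 the expected step is therefore a 1.0-fold higher number from compound 2 to compound 4 (0.01 log units; within the scatter), none beyond the scatter. Compound 4 is estimated at 5.5 mL/min/kg, with a range from 3 mL/min/kg to 10 mL/min/kg.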

Compound 4, clearance: 1.37 mL/min/kg
For compound 4 the middle estimate is 4.0-fold (0.60 log units) above the measured one; measured number outside the range, below it.
By their numbers in this assay, from the lowest: compound 4; then compounds 2 and 1 (each within the scatter of the next).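

In this assay, fluoro in place of hydrogen on an aromatic carbon, ortho to a chloro group, gives a 3.9-fold lower number from compound 2 to compound 4 (0.60 log units; beyond the scatter) and is the only step shown that lies beyond the scatter. Clearance therefore responds to the change from 4-chlorophenyl to 4-chloro-3-fluorophenyl, whereas the methyl on the saturated ring carbon left it within the scatter. Nothing given here accounts for this step. The compounds shown leave open whether another group at this position, such as methoxy or a second chloro, gives a similar step, and whether fluoro does so without the methyl of compound 2.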